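This account rests on a few compounds, and the source may have more. Where it says the series, first, only, none or still open, it means among the compounds named here.

Measured in an in vivo ADME assay on the whole organism (plasma, strain Sprague-Dawley) for pharmacokinetics, with Rattus norvegicus as the target; a lower number here means slower removal, a higher number faster removal of the compound:
- Compound 1 `O=C1[C@@H](NS(=O)(=O)c2ccc3cc(Cl)ccc3c2)CCN1c1ccc2c(c1)CCNC2`: 4 mL/min/kg
- Compound 2 `O=C1[C@@H](NS(=O)(=O)c2ccc3cc(Cl)ccc3c2)CCN1c1ccc2c(c1F)CCNC2`: 2.1 mL/min/kg
- Compound 3 `O=C1[C@@H](NS(=O)(=O)c2ccc3c(Cl)c[nH]c3c2)CCN1c1ccc2c(c1F)CCNC2`: 2.7 mL/min/kg

The values of these three compounds lie within the scatter of one another, so compound 1 does not stand apart from either of the others in this assay. Compound 4 `O=C1[C@@H](NS(=O)(=O)c2ccc3cc(Cl)ccc3c2)CCN1c1cc2c(cc1F)CNCC2` has not yet been measured. It differs from compound 1 by fluoro in place of hydrogen on an aromatic carbon, ortho to a large group, meta to a fused ring and para to a fused ring.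

Among the measured compounds shown here, one measured step bears on this change. It is also a fluoro replacing a hydrogen, a 1.9-fold lower number from compound 1 to compound 2 (0.28 log units; within the scatter), and it stays within the scatter. In compound 2, however, the fluoro stands on a different aromatic carbon, so this step is only a partial guide. No step beyond the scatter is therefore expected in this assay. The estimated step is a 1.3-fold lower number from compound 1 to compound 4 (0.12 log units; within the scatter). For compound 4 the expected value is 3 mL/min/kg, with an estimated range of 1.5 mL/min/kg to 6 mL/min/kg.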

Compound 4, clearance: 1.7 mL/min/kg
Compound 4: middle estimate off by 1.8-fold (0.25 log units), on the high side; the measured number falls inside the stated range.
By their numbers in this assay, from the lowest: compounds 4, 2, 3 and 1 (each within the scatter of the next, the first and the last beyond it).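

In this assay, fluoro in place of hydrogen on this aromatic carbon, ortho to a large group, meta to a fused ring and para to a fused ring, gives a 2.4-fold lower number from compound 1 to compound 4 (0.37 log units; beyond the scatter), the only single-place step among these compounds that is printed as beyond the scatter. The earlier fluoro step, on a different aromatic carbon, gave a 1.9-fold lower number from compound 1 to compound 2 (0.28 log units; within the scatter) and stayed within the scatter, so the position of the fluoro may matter, although the effect here is modest. Nothing available explains this lower clearance.

The compounds shown leave open whether a chloro, methyl or methoxy group on this same carbon would give a similar number. They also leave open whether this fluoro step would hold with the other sulfonyl-bound group seen in compound 3.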